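Swapping a Small Ring for a Larger Oxygen-Containing One

The source may report more compounds than this note shows. Statements on the series, on what has been measured and on what is new or still open speak of the compounds shown alone.

Compound 2 `CCn1ncc(-c2nc3c(O[C@H]4CCN(C(=O)C5CC5)C4)ncnc3n2C)c1C`: 41%
Compound 1 `CCn1ncc(-c2nc3c(N4CCC(n5c(=O)[nH]c6ncccc65)CC4)ncnc3n2C)c1C`: 95%

In an ADME assay on a cell-free system (plasma, Canis lupus familiaris, strain Beagle) for protein binding, compound 2 gives 41%, the larger free share of the two values, while compound 1 gives 95%, a gap well beyond the usual scatter. Compound 3 `CCn1ncc(-c2nc3c(O[C@H]4CCN(C(=O)C5CCOCC5)C4)ncnc3n2C)c1C` has not been measured. It differs from compound 2 by oxan-4-yl in place of cyclopropyl on a carbonyl carbon. Among the compounds with values here, no measured pair shows this kind of change, so the step is expected to be small, within the scatter, if anything slightly toward less binding. Compound 3 is therefore estimated at 38%, with a range from 20% to 60%. This amounts to an expected step of a 1.1-fold higher unbound fraction from compound 2 to compound 3 (0.02 log units; within the scatter).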

Compound 3, plasma protein binding: 26%
Estimate against measurement, compound 3: 1.2-fold (0.08 log units) (unbound fraction) below; the measured number falls inside the stated range.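

In this assay, oxan-4-yl in place of cyclopropyl on the carbonyl carbon gives a 1.3-fold higher unbound fraction from compound 2 to compound 3 (0.10 log units; within the scatter), so at this position a larger ring carrying one hydrogen-bond acceptor leaves the result within the usual scatter of repeat measurements. Within the data shown here, with only this single swap, the effect is small, and nothing measured here accounts for it. Still open, from the compounds shown here alone, is whether a ring carrying an amine or a carboxylic acid at this place would shift plasma protein binding beyond that scatter. A single step also cannot show whether the same swap would behave alike on another core.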